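Removing a Dimethylamino Group: What Inhibition to Expect

The source may report more compounds than this note shows. Statements on the series, on what has been measured and on what is new or still open speak of the compounds shown alone.

Of the compounds shown here, two have been measured in a functional assay (Homo sapiens) for inhibition of Nucleic Acid, tested at 100 uM; on this read-out lower numbers stand for less inhibition and higher numbers for more inhibition at the one concentration tested (going by the name of the read-out). Compound 1 `CN(C)c1nccc2c1ncn2[C@H]1C[C@H](O)[C@@H](CO)O1` gives 0%, the lowest of the two numbers, while compound 2 `[N-]=[N+]=Nc1nccc2c1ncn2C1O[C@H](CO)[C@@H](O)[C@H]1O` gives 4%; the gap between them sits within the usual scatter of repeated measurements, so the two values cannot be told apart. Neither compound shows meaningful inhibition at the single concentration tested.

Compound 3 `OC[C@H]1O[C@@H](n2cnc3cnccc32)C[C@@H]1O` has not yet been measured. It differs from compound 1 in one place: hydrogen in place of dimethylamino on an aromatic carbon. Among the compounds with values here, no step between two measured compounds is known, so the size of any change must be judged from the two values alone, and both lie near zero.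

Compound 1 and compound 2 both sit at the bottom of the read-out in this assay, and a reading of zero leaves no room for a drop. The expected step is therefore a number 2 percentage points higher from compound 1 to compound 3 (within the scatter), nothing beyond the scatter. Compound 3 is estimated at 2%, within a range from -8% to 12%.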

Compound 3, a percentage reported as inhibition, at one concentration (the size of the read-out at that concentration, not a potency): 6%
Estimate against measurement, compound 3: 4 percentage points below; measured number inside the range.
By their numbers in this assay, from the lowest: compounds 1, 2 and 3 (each within the scatter of the next).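

Replacing the dimethylamino group with hydrogen on this aromatic carbon in this assay gives a number 6 percentage points higher from compound 1 to compound 3 (within the scatter), so this change does not separate the two compounds. Within the data shown here, this is the first step that can be read at this position, and it shows that a group of 3 heavy atoms can go without the read-out leaving the low end of its range. The limit of that finding is that compound 1 sits at the very bottom of the read-out, so there was no measurable inhibition for the change to remove, and the step shows only that hydrogen brings no gain beyond the scatter. No measurement here bears on what lies behind this result.

Still open, as far as these compounds go, is whether a different group on this carbon, such as a primary amine, a methoxy group or a longer alkyl chain, would move the number beyond the scatter when set on the core of compound 3. Also open, from the compounds shown here alone, is whether this position matters at all at a concentration other than the one tested, since a single reading near zero gives no measure of potency.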